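Swapping hydroxy for sulfanyl on a fused two-ring core

A few compounds are considered here, and "the series" means these few. Any claim that something is new, unique, unknown or untested is made for them only; others in the source may bear on it.

Of the compounds shown here, three have been measured in an assay for inhibition of Dihydrofolate reductase (Homo sapiens); a higher number here means a more potent compound, by a factor of ten per unit of this negative logarithm, a lower number a less potent compound. Compound 1 `Sc1nc(S)c2cc(Sc3ccc4ccccc4c3)ccc2n1` gives 5.05. Compound 3 `Oc1nc(S)nc2ccc(Sc3ccc4ccccc4c3)cc12` gives 5. Compound 2 `Nc1nc(O)nc2ccccc12` gives 4.02, the lowest of the three numbers, beyond the scatter from both others.

Compounds 3 and 1 differ in one place: sulfanyl in place of hydroxy on an aromatic carbon. That change produced a number 0.05 log units higher from compound 3 to compound 1 (within the scatter).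

Compound 4 `Nc1nc(S)nc2ccccc12` has not yet been measured in this assay. It arises from compound 2 by the same kind of change: sulfanyl in place of hydroxy on an aromatic carbon. The surroundings are not identical, though. In compound 3 the exchanged group sits next to the ring nitrogen, ortho to a fused ring and meta to a sulfanyl group, opposite the ring nitrogen; in compound 2 it sits between two ring nitrogen atoms, meta to an amino group and para to a fused ring. The difference between the two cores is not broken down here.

Because the step of a number 0.05 log units higher from compound 3 to compound 1 (within the scatter) was within the scatter, a similarly small step is expected for compound 4, namely a number 0.08 log units higher from compound 2 to compound 4 (within the scatter). Compound 4 is therefore estimated to give 4.1, plausibly between 3.6 and 4.6.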

Compound 4, logarithm of the reciprocal of the active concentration, log(1/C): 3.72
Compound 4: middle estimate off by 0.38 log units, on the high side, within the range that was stated.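

In this assay, within the data shown here, placing sulfanyl where hydroxy stood on the aromatic carbon between two ring nitrogen atoms gave a number 0.30 log units lower from compound 2 to compound 4 (within the scatter), so this exchange again produced no step that stands clear of the usual variation between repeated measurements. Set side by side, the two results give no sign that the exchange behaves differently on the two cores: the same change on two cores in this assay, a number 0.05 log units higher (within the scatter) from compound 3 to compound 1 and a number 0.30 log units lower (within the scatter) from compound 2 to compound 4, 0.35 log units apart, within the scatter of two such steps. Among these compounds, this supports carrying the exchange from one of these cores to the other as a small step, but it rests on only two pairs of compounds, and it cannot show that the exchange has no effect at all, since a small real step could be hidden within the scatter.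

The compounds shown leave open how a methoxy group or a chlorine atom would compare with hydroxy and sulfanyl on the same aromatic carbon. They also leave open whether the exchange stays this small on any core beyond these two.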